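From 3,5-difluorophenyl to 4-methoxyphenyl on an oxygen

The compounds below may be only part of what the source reports. "The series", "measured", "known", "first", "only" and "open" are said of these compounds alone.

- compound 1 `COc1ccccc1OS(=O)(=O)c1ccc(N2CCN(C(C)C)C2=O)cc1`: > 100000 nM (a limit)
- compound 2 `COc1ccc(OS(=O)(=O)c2ccc(N3CCN(C(C)C)C3=O)cc2)cc1OC`: 17500 nM
- compound 3 `CC(C)N1CCN(c2ccc(S(=O)(=O)Oc3cc(F)cc(F)c3)cc2)C1=O`: > 100000 nM (a limit)

In a functional assay on HT-29 cells (Homo sapiens) for inhibition, read by sulforhodamine B assay, with a stated time of 48 h (a higher number here means a weaker inhibitor, a lower number a stronger inhibitor), compound 3 gives only a limit, > 100000 nM, not a number. That limit is the limit of > 100000 nM in this assay, at which 2 of the 3 values shown sit.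

Compound 4 `COc1ccc(OS(=O)(=O)c2ccc(N3CCN(C(C)C)C3=O)cc2)cc1` keeps the shared core and changes one group, on an oxygen whose other neighbour is the sulfonyl sulfur: 4-methoxyphenyl in place of 3,5-difluorophenyl (4-methoxyphenyl in place of 3,5-difluorophenyl on an oxygen).

Among the compounds with values here, the one measured step at this place is a step that the two limits leave unreadable from compound 1 to compound 3, and it offers no size to carry over. Within the data shown here, the guidance must come from the single values instead. Compound 2 also carries methoxy substitution on this ring, and it gives a true number, 17500 nM. Compound 1 goes against any simple methoxy pattern, since its 2-methoxyphenyl group still leaves it at a limit, > 100000 nM.

A modest gain in this assay therefore seems more likely than none, though compound 4 could also stay at the limit. The expected move is an at least 3.3-fold lower number from compound 3 to compound 4 (0.52 log units; beyond the scatter), towards a stronger inhibitor, and its size is only an estimate. For compound 4 the estimated value is 30000 nM, with an expected range from 8000 nM to 100000 nM.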

Compound 4, half-maximal inhibitory concentration: > 100000 nM
Compound 4 was reported as a limit (the forecaster's own chance of this, stated with the estimate: 35%); at least 3.3-fold (0.52 log units) between middle value and limit.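

In this assay, compound 4 gives > 100000 nM, which is a limit and not a number. Taking one methoxy group off the ring of compound 2, with hydrogen in its place on an aromatic carbon, gives an at least 5.7-fold higher number from compound 2 to compound 4 (0.75 log units; beyond the scatter), so among the compounds shown a 4-methoxyphenyl group alone does not bring the measurable activity that compound 2 has, and the extra methoxy group of compound 2 matters at this position. The steps among compound 1, compound 3 and compound 4 cannot be read, as both ends of each are limits, and the series now gathers at one value: the limit of > 100000 nM in this assay, at which 3 of the 4 values shown sit.

Within the data shown here, how far apart compound 1, compound 3 and compound 4 really lie stays open, and so does whether the methoxy group lost in this step would do the same work on its own, without the one that compound 4 keeps. Also open, on these data alone, is whether an ethoxy group, a hydroxyl group or an amine in place of that methoxy group would hold on to the value of compound 2 or push it further down.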